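Alpha-2B binding: ring substituent changes on the shared core

The source may hold more compounds than are shown below. What is called first, only, known or untested is meant among the compounds shown, and "the series" means these compounds.

Compound 1 `CC(Oc1ccccc1Br)C1=NCCN1`: in an assay on CHO cells for displacement of a labelled ligand from Alpha-2B adrenergic receptor (Homo sapiens) (a higher number here means a weaker inhibitor, a lower number a stronger inhibitor), compound 1 gives 355 nM.
Compound 2 `CCc1ccccc1OC(C)C1=NCCN1`: compound 2 gives 282 nM.
Compound 3 `CC(C)Oc1ccccc1OC(C)C1=NCCN1`: compound 3 gives 1580 nM.

Compound 3 has the highest number of the three: a 4.5-fold higher number from compound 1 to compound 3 (0.65 log units; beyond the scatter) and a 5.6-fold higher number from compound 2 to compound 3 (0.75 log units; beyond the scatter), both beyond the scatter. Compound 4 `COc1ccccc1OC(C)C1=NCCN1` differs from compound 3 by methyl in place of isopropyl on an oxygen on an aromatic ring. Among the measured compounds shown here, no measured step changes this group alone; the steps that bear on it are the two above, in which isopropoxy entering raised the number by a modest amount. With the smaller alkyl now on that oxygen, a partial return toward the numbers of compounds 1 and 2 is expected, a downward step of a 2.6-fold lower number from compound 3 to compound 4 (0.42 log units; beyond the scatter). Compound 4 is therefore estimated at 600 nM, with a range of 250 nM to 1500 nM.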

Compound 4, inhibition constant: 871 nM
Compound 4: the middle estimate sits 1.5-fold (0.16 log units) below what was measured; the measured number falls inside the stated range.
By their numbers in this assay, from the lowest: compounds 2 and 1 (each within the scatter of the next); then compounds 4 and 3 (each within the scatter of the next).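

Methyl in place of isopropyl on the oxygen gives a 1.8-fold lower number from compound 3 to compound 4 (0.26 log units; within the scatter), so this pair does not separate the two alkyl groups in this assay. The higher numbers are therefore not confined to isopropoxy: methoxy also stands apart from ethyl and bromo, with a 3.1-fold higher number from compound 2 to compound 4 (0.49 log units; beyond the scatter) and a 2.5-fold higher number from compound 1 to compound 4 (0.39 log units; beyond the scatter). No evidence on the cause of this shift is available.

Still open, going by these compounds, is whether a hydroxy group or a longer chain such as butoxy would stay with the two alkoxy compounds. On these data alone, it is also open whether an amine would stay with ethyl and bromo instead.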